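A few compounds are considered here, and "the series" means these few. Any claim that something is new, unique, unknown or untested is made for them only; others in the source may bear on it.

Compound 1 `O=[N+]([O-])c1cccc(Nc2nnc(-c3c[nH]c4ccccc34)o2)c1`: > 100000 nM
Compound 2 `O=[N+]([O-])c1ccc(Nc2nnc(-c3c[nH]c4ccccc34)o2)cc1`: 45000 nM

Among the measured compounds shown here, in a functional assay on Jurkat cells (Homo sapiens) for inhibition, with a stated time of 24 h (on this read-out lower numbers stand for stronger inhibition and higher numbers for weaker inhibition), compound 2 gives 45000 nM as the only true number so far. Compound 1 reads > 100000 nM as a limit of the assay, not a number. Compound 3 `Fc1ccc(Nc2nnc(-c3c[nH]c4ccccc34)o2)cc1` has fluoro in place of nitro on an aromatic carbon, para to a large group (fluoro in place of nitro on an aromatic carbon). For the measured compounds named here, no measured pair shows this swap, so only a modest shift toward weaker inhibition is expected. The estimated 1.3-fold higher number from compound 2 to compound 3 (0.12 log units; within the scatter) is small and may stay within the usual scatter. For compound 3 the expected value is 60000 nM with 20000 nM to 100000 nM as its range.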

Compound 3, half-maximal inhibitory concentration: > 100000 nM
Compound 3: only a limit was reported; the forecaster's own chance of this, stated with the estimate: 35%; middle value at least 1.6-fold (0.22 log units) away from the limit.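

On an aromatic carbon para to a large group, fluoro in place of nitro gives an at least 2.2-fold higher number from compound 2 to compound 3 (0.34 log units; beyond the scatter) and so weaker inhibition. Among the three compounds, only compound 2, with nitro in this place, gives a true number. Compound 3 reads as a limit and not a number, so the real size of this step stays unknown because the read-out stops there: the limit of > 100000 nM in this assay, at which 2 of the 3 values shown sit.

From the compounds shown here alone, whether an amine or a carboxylic acid in this place would match or beat compound 2 remains open.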